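Removing the chloro from the benzoyl arm of compound 3

This account rests on a few compounds, and the source may have more. Where it says the series, first, only, none or still open, it means among the compounds named here.

Measured compounds:
- Compound 1, `COc1ccc(C(=O)NCc2ccc(CNS(=O)(=O)c3ccccc3)cc2)cc1`: 1000 nM
- Compound 2, `O=C(NCc1ccc(CNS(=O)(=O)c2ccccc2)cc1)c1cccnc1`: 10 nM
- Compound 3, `O=C(NCc1ccc(CNS(=O)(=O)c2ccccc2)cc1)c1cccc(Cl)c1`: 1000 nM

Compound 3 stands level with compound 1 on an assay on MDA-MB-231 cells for binding affinity to C-X-C chemokine receptor type 4 (Homo sapiens), read by immunofluorescence and microscopy, with stated times of 10 min and 30 min (a lower number here means that less compound is needed, a higher number that more compound is needed for the effect), the two together giving the highest numbers of the three. Within the data shown here, the only compound set apart is compound 2, which is reached through a 100-fold lower number from compound 1 to compound 2 (2.00 log units; beyond the scatter); the reverse view is a 100-fold higher number from compound 2 to compound 3 (2.00 log units; beyond the scatter). Between compound 1 and compound 3 there is no change at the digits printed from compound 1 to compound 3 (within the scatter).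

Compound 4, `O=C(NCc1ccc(CNS(=O)(=O)c2ccccc2)cc1)c1ccccc1`, differs from compound 3 as hydrogen in place of chloro on an aromatic carbon, so that 3-chlorophenyl becomes phenyl on the carbonyl carbon. Among the measured compounds shown here, no measured step changes a single substituent on this ring; the nearest guide is the step from compound 1 to compound 3, where one substituted phenyl replaced another, with no change at the digits printed from compound 1 to compound 3 (within the scatter). The large step belonged to pyridin-3-yl alone. On that basis the change from compound 3 to compound 4 is expected to give no change at the digits printed from compound 3 to compound 4 (within the scatter), with compound 4 estimated at 1000 nM in this assay, ranging from 300 nM to 3000 nM.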

Compound 4, effective concentration (reported as EC, without a stated level of effect): 1 nM
For compound 4 the middle estimate is 1000-fold (3.00 log units) above the measured one; measured number below the stated range.
By their numbers in this assay, from the lowest: compound 4; then compound 2; then compounds 1 and 3 (each within the scatter of the next).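

In this assay, the unsubstituted phenyl arm shows what the level values of compound 1 and compound 3 could not: a 1000-fold lower number from compound 3 to compound 4 (3.00 log units; beyond the scatter) and a 1000-fold lower number from compound 1 to compound 4 (3.00 log units; beyond the scatter), so each of these two substituents goes with a large rise in the number. That agreement between compound 1 and compound 3 therefore does not mean that this ring is indifferent to substitution. The pyridin-3-yl ring also loses its special standing, with a 10-fold lower number from compound 2 to compound 4 (1.00 log units; beyond the scatter), so a low number on this arm does not depend on that ring.

On these data alone, whether a smaller group such as fluoro, or an amine, on this ring would also raise the number remains open, as does the effect of moving the chloro elsewhere on it. Nothing available here explains the size of these steps.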